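Phenoxy-benzyl thymine series: cytotoxicity working notes

A few compounds are considered here, and "the series" means these few. Any claim that something is new, unique, unknown or untested is made for them only; others in the source may bear on it.

The compounds share the core of compound 1 `Cc1cn(C2CCN(Cc3cc(Oc4ccccc4)ccn3)CC2)c(=O)[nH]c1=O` and differ in the aryl ether arm. In an ADME assay on MRC5 cells (Homo sapiens) for cytotoxicity, read by fluorescence and resazurin assay, with a stated time of 3 days (a higher number here means a weaker inhibitor, a lower number a stronger inhibitor), compound 1 reaches only a limit, > 64000 nM. Compound 3 `Cc1cn(C2CCN(Cc3cccc(Oc4ccccc4)n3)CC2)c(=O)[nH]c1=O` in this assay likewise gives only a limit, > 64000 nM. Among the compounds with values here, compound 2 `Cc1cn(C2CCN(Cc3cccc(Oc4ccc(Cl)cc4)c3)CC2)c(=O)[nH]c1=O` in this assay gives 25100 nM, the one measured number in the set. The rest of the set sits at the limit of > 64000 nM in this assay, at which 2 of the 3 values shown sit. Compound 4 `Cc1cn(C2CCN(Cc3cccc(Oc4ccc(Cl)c(Cl)c4)c3)CC2)c(=O)[nH]c1=O` carries the change (chloro in place of hydrogen on an aromatic carbon). Within the data shown here, no measured step covers this change; with compound 2 as the only anchor, a modest move toward a lower number is expected, close to the scatter. The step from compound 2 to compound 4 is estimated at a 1.7-fold lower number from compound 2 to compound 4 (0.22 log units; within the scatter). Compound 4 is expected near 15000 nM, within 6000 nM to 40000 nM.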

Compound 4, half-maximal inhibitory concentration: 6100 nM
Beside the measured number, compound 4's estimate is 2.5-fold (0.39 log units) above it; the measured number falls inside the stated range.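

In this assay, within the data shown here, the change from 4-chlorophenoxy to 3,4-dichlorophenoxy gives the first measured step: a 4.1-fold lower number from compound 2 to compound 4 (0.61 log units; beyond the scatter). On this one pair, a chloro on this aromatic carbon, ortho to the existing chloro group, moves the number beyond the scatter. Compound 1 and compound 3 add no number to this reading, only a limit: the limit of > 64000 nM in this assay, at which 2 of the 4 values shown sit.

As far as these compounds go, whether an amine, a methoxy group or a nitrile on the same carbon would give a step of similar size remains open. Also open, from the compounds shown here alone, is whether the same chloro would shift the number on the aryl ether arms of compound 1 and compound 3.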